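The source may hold more compounds than are shown below. What is called first, only, known or untested is meant among the compounds shown, and "the series" means these compounds.

In an ADME assay on HeLa cells (Homo sapiens) for inhibition, read by MTT assay, with a stated time of 48 h (a lower number here means a stronger inhibitor, a higher number a weaker inhibitor), compound 1 `N#Cc1ccc(Cn2cc(/C=C/C(=O)CC(=O)C(=O)O)c3ccccc32)cc1` gives > 40000 nM, which is a limit of the assay and not a number. As far as these compounds go, compound 2 `COc1ccc(Cn2cc(/C=C/C(=O)CC(=O)C(=O)O)c3ccccc32)cc1` gives > 40000 nM, also a limit, so its true position is unknown. The next compound, compound 3 `CN(C)C(=O)Cn1cc(/C=C/C(=O)CC(=O)C(=O)O)c2ccccc21`, differs from compound 2 at one place: dimethylcarbamoyl in place of 4-methoxyphenyl on a saturated chain carbon bound to an aromatic nitrogen. For the measured compounds named here, only one measured step bears on this change. It is a step that the two limits leave unreadable from compound 1 to compound 2, with methoxy in place of cyano, and its size cannot be read. All the evidence so far is the limit of > 40000 nM in this assay, at which 2 of the 2 values shown sit. With no measurable activity yet to build on, no clear gain in this assay is expected, and the estimated outcome is a step that the limit leaves unreadable from compound 2 to compound 3. For compound 3 the estimated value is 50000 nM, with an expected range from 20000 nM to 120000 nM.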

Compound 3, half-maximal inhibitory concentration: > 40000 nM
Compound 3: no number, only a limit; the forecaster's own chance of this, stated with the estimate: 80%; the middle value does not contradict the limit.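

Compound 3, like compound 1 and compound 2, gives only a limit of this assay and not a number, so the steps among these three compounds cannot be read: the limit of > 40000 nM in this assay, at which 3 of the 3 values shown sit.

As far as these compounds go, whether 4-cyanophenyl, 4-methoxyphenyl or dimethylcarbamoyl at this place changes the inhibition at all stays open.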